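The compounds below may be only part of what the source reports. "The series", "measured", "known", "first", "only" and "open" are said of these compounds alone.

In an ADME assay on Huh-7 cells (Homo sapiens) for cytotoxicity (a lower number here means that less compound is tolerated, a higher number that more compound is tolerated), compound 1 `Cc1ccccc1-c1nn(-c2ccc(C(F)(F)F)cc2)cc1CNCCN1CCN(C)CC1` gives 11000 nM, and compound 2 `CSc1ccc(-n2cc(CNCCN3CCN(C)CC3)c(-c3ccccc3C)n2)cc1` gives 17000 nM; the pair stands apart only by a 1.5-fold higher number from compound 1 to compound 2 (0.19 log units; within the scatter), so compound 2 cannot be told from compound 1 on these numbers. Compound 3 `Cc1ccccc1-c1nn(-c2cccc(C(F)(F)F)c2)cc1CNCCN1CCN(C)CC1` carries 3-(trifluoromethyl)phenyl in place of 4-(methylsulfanyl)phenyl on an aromatic nitrogen. Among the measured compounds shown here, the one measured step bearing on this exchange is a 1.5-fold higher number from compound 1 to compound 2 (0.19 log units; within the scatter), which did not leave the scatter, so no step beyond the scatter is expected in this assay for this change either. For compound 3 the estimate in this assay is 12000 nM (range 6000 nM to 25000 nM), an expected step of a 1.4-fold lower number from compound 2 to compound 3 (0.15 log units; within the scatter).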

Compound 3, half-maximal cytotoxic concentration: 18000 nM
The estimate for compound 3 lay 1.5-fold (0.18 log units) below the measured number, within the range that was stated.
By their numbers in this assay, from the lowest: compounds 1, 2 and 3 (each within the scatter of the next).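

In this assay, 3-(trifluoromethyl)phenyl in place of 4-(trifluoromethyl)phenyl on the aromatic nitrogen gives a 1.6-fold higher number from compound 1 to compound 3 (0.21 log units; within the scatter), and 3-(trifluoromethyl)phenyl in place of 4-(methylsulfanyl)phenyl gives a 1.1-fold higher number from compound 2 to compound 3 (0.02 log units; within the scatter). Among the compounds shown here, this position has now taken both a shift of the trifluoromethyl around the phenyl and an exchange of the group itself, with no step leaving the scatter. No evidence accompanies these numbers. From the compounds shown here alone, whether a carboxylic acid or an amine on that phenyl would leave the scatter remains open, as does any change elsewhere on the shared core.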